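Fluoro to Methyl: Expecting No Change Beyond Scatter

The source may hold more compounds than are shown below. What is called first, only, known or untested is meant among the compounds shown, and "the series" means these compounds.

Three related compounds have been measured in a functional assay on MCF7 cells (Homo sapiens) for inhibition, read by CCK-8 assay, with a stated time of 48 h; a higher number here means a weaker inhibitor, a lower number a stronger inhibitor. Compound 1 `O=C(NC(=S)Nc1ccc(F)cc1)c1cn(-c2ccccc2)nc1-c1ccc(F)cc1` gives 5610 nM. Compound 2 `O=C(NC(=S)Nc1ccc(Cl)cc1)c1cn(-c2ccccc2)nc1-c1ccc(Cl)cc1` gives 5360 nM, and compound 3 `Cc1ccc(NC(=S)NC(=O)c2cn(-c3ccccc3)nc2-c2ccc(F)cc2)cc1` gives 5440 nM. Compound 1 has the highest of the three numbers, but its gaps to compound 3 and to compound 2 both lie within the usual scatter of repeated measurements, so none of the three can be called stronger or weaker than another.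

Compound 4 `Cc1ccc(-c2nn(-c3ccccc3)cc2C(=O)NC(=S)Nc2ccc(F)cc2)cc1` has not yet been measured. It differs from compound 1 in a single place: methyl in place of fluoro on an aromatic carbon. Within the data shown here, the measured step that bears on this most closely is the one from compound 1 to compound 3, where the same exchange of groups was made on a different ring of the shared core and a 1.0-fold lower number from compound 1 to compound 3 (0.01 log units; within the scatter). The values of compound 1 and compound 2 likewise sit within the scatter of each other. Nothing among these compounds suggests that swapping one small group on an aromatic carbon moves the number beyond the scatter, so the step from compound 1 to compound 4 is expected to be a 1.0-fold lower number from compound 1 to compound 4 (0.00 log units; within the scatter). For compound 4 the estimated value in this assay is 5600 nM, with a range from 2800 nM to 11000 nM.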

Compound 4, half-maximal inhibitory concentration: 6420 nM
Estimate against measurement, compound 4: 1.1-fold (0.06 log units) below, and the stated range covers the measured number.
By their numbers in this assay, from the lowest: compounds 2, 3, 1 and 4 (each within the scatter of the next).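

In this assay, exchanging the fluoro group on the second fluorinated ring of compound 1 gives a 1.1-fold higher number from compound 1 to compound 4 (0.06 log units; within the scatter). Together with a 1.0-fold lower number from compound 1 to compound 3 (0.01 log units; within the scatter), this means that each of the two fluoro groups of compound 1 has now been replaced by methyl, one at a time, and neither single exchange moves the number beyond the scatter, so the earlier result on one ring now has a counterpart on the other. What this adds is limited but useful: at this position, on a six-membered aromatic ring of carbon only, 4-fluorophenyl and 4-methylphenyl cannot be told apart in this measurement, and no information is available that would explain this.

The compounds shown leave open whether a group of a quite different kind at this position, such as an amine, a carboxylic acid or a longer chain like butyl, would shift the number beyond the scatter, or whether this position simply has little bearing on the read-out. They also leave open what would happen with methyl on both rings at once, since each exchange shown here was made alone.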